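The compounds below may be only part of what the source reports. "The series", "measured", "known", "first", "only" and "open" are said of these compounds alone.

Measured so far:
- compound 1, `O=S(=O)(/C=C/c1ccccn1)c1ccccc1F`: 1050 nM
- compound 2, `O=S(=O)(/C=C/c1ncccc1F)c1ccccc1F`: 176 nM

In an assay on U2OS cells for activation of nuclear factor erythroid 2-related factor 2 (Homo sapiens), read by beta-arrestin recruitment, with a stated time of 6 h (on this read-out lower numbers stand for an effect already at smaller amounts and higher numbers for an effect only at larger amounts of compound), compound 1 gives 1050 nM and compound 2 gives 176 nM. Going by the values given here, the one measured step, a 6.0-fold lower number from compound 1 to compound 2 (0.78 log units; beyond the scatter), is the only comparison available. Compound 2 thus stands with the lowest number of the two in this assay.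

Compound 3, `O=S(=O)(/C=C\c1ncccc1F)c1ccccc1F`, is the next step. Compared with compound 2: the two compounds have the same atoms and bonds and differ only in configuration as drawn: 1 of 1 stereo elements differ; a double bond is drawn E in compound 2 and Z in compound 3. No measured step in the set concerns a change of double-bond geometry, so nothing shown bears directly on this step. In this assay the effect of the change is therefore open; a drawn change of configuration may leave the number unchanged or shift it in either direction, and a wide range is appropriate.

The working expectation for compound 3 is 500 nM, within 120 nM to 3000 nM. This estimate corresponds to a 2.8-fold higher number from compound 2 to compound 3 (0.45 log units; beyond the scatter), a step that is expected rather than shown.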

Compound 3, half-maximal effective concentration: 482 nM
Compound 3: the middle estimate sits 1.0-fold (0.02 log units) above what was measured; the measured number falls inside the stated range.
By their numbers in this assay, from the lowest: compound 2; then compound 3; then compound 1.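

In this assay, the double-bond geometry alone moves the number, giving a 2.7-fold higher number from compound 2 to compound 3 (0.44 log units; beyond the scatter). No group enters or leaves in this step, so the shift can be assigned to configuration alone: the fact that compounds 2 and 3 differ only in the configuration as drawn. The earlier compounds shown here showed a response only to fluoro in place of hydrogen on an aromatic carbon, whereas the double bond now stands as a second place where the number changes, with the E drawing giving the lower number of this pair.

As far as these compounds go, whether the same order of E and Z holds without that added fluoro remains open. Also open, from the compounds shown here alone, are the effects of an amine or a carboxylic acid in place of the fluoro, and of a saturated two-carbon chain in place of the double bond.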